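The source may report more compounds than this note shows. Statements on the series, on what has been measured and on what is new or still open speak of the compounds shown alone.

Working notes on the series. In a functional assay on EC9706 cells (Homo sapiens) for antiproliferative activity, read by MTT assay, with a stated time of 72 h (a lower number here means a stronger inhibitor, a higher number a weaker inhibitor), compound 1 (`C/C(=N\NC(=O)c1cccc(S(=O)(=O)N2CCOCC2)c1)c1cccc(N)c1`) gives > 100000 nM, which is a limit of the assay and not a number. Compound 2 (`C/C(=N\NC(=O)c1cccc(S(=O)(=O)N2CCOCC2)c1)c1cccc(N)c1O`) gives 3520 nM. Compound 3 (`O=C(N/N=C/c1ccccc1O)c1cccc(S(=O)(=O)N2CCOCC2)c1`) gives 19600 nM, the higher of the two true numbers, and its gap to compound 2 lies beyond the scatter.

Compound 4 (`O=C(N/N=C/c1cc(Br)ccc1O)c1cccc(S(=O)(=O)N2CCOCC2)c1`) goes from 2-hydroxyphenyl in compound 3 to 5-bromo-2-hydroxyphenyl: bromo in place of hydrogen on an aromatic carbon. The bromo stands on an aromatic carbon, para to a hydroxy group and meta to a large group.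

For the measured compounds named here, no measured step introduces a bromo. Going by the values given here, the only step with a bearing is an at least 28-fold lower number from compound 1 to compound 2 (1.45 log units; beyond the scatter), a large change that comes from hydroxy in place of hydrogen on an aromatic carbon. It shows that one replacement on an aromatic carbon can move the number in this assay a long way, but it is a different group, so neither its size nor its direction carries over directly. A modest step toward a lower number is therefore expected, and a result within the scatter of compound 3 remains possible.

The estimated change is a 2.2-fold lower number from compound 3 to compound 4 (0.34 log units; beyond the scatter). For compound 4 the expected value is 9000 nM, with an estimated range of 2500 nM to 32000 nM.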

Compound 4, half-maximal inhibitory concentration: 29700 nM
Compound 4: the middle estimate sits 3.3-fold (0.52 log units) below what was measured, within the range that was stated.
By their numbers in this assay, from the lowest: compound 2; then compounds 3 and 4 (each within the scatter of the next). At a limit, above all of these: compound 1.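

In this assay, for the compounds shown here, bromo in place of hydrogen on an aromatic carbon, para to a hydroxy group and meta to a large group, gives a 1.5-fold higher number from compound 3 to compound 4 (0.18 log units; within the scatter), so this is the first replacement that leaves the number within the scatter. The earlier large step came from a hydroxy group on a different pair of compounds, and the present step shows that a replacement on an aromatic carbon does not by itself move the number in this assay; at this place, a single bromine atom is accepted with no change that can be told from the scatter. Going by these compounds alone, nothing at hand gives a cause for this step, and the one limit among the values shown does not bear on it.

A single group at a single place cannot show whether this place is insensitive in general, and an amine, a carboxylic acid or a longer chain such as ethoxy at the same carbon could still give a step beyond the scatter. As far as these compounds go, it also remains open whether the same bromo would behave alike on the core of compound 2, which carries the lowest number of the set.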